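A few compounds are considered here, and "the series" means these few. Any claim that something is new, unique, unknown or untested is made for them only; others in the source may bear on it.

Compound 3 `C=C1C2=C(C(=O)N1OC)[C@H](O)[C@@](C)(O)[C@H](CCCCC)O2` carries a free hydroxy group on its core. In a functional assay on MCF7 cells (Homo sapiens) for cytotoxicity, read by MTT assay, with a stated time of 72 h (on this read-out higher numbers stand for weaker inhibition and lower numbers for stronger inhibition), compound 3 gives 20000 nM, the highest number of the three measured compounds, and its gaps to the other two lie beyond the scatter. Among the compounds with values here, compound 1 `C=C1C2=C(C(=O)N1OC)[C@H](OC(=O)CSc1nc3ccccc3o1)[C@@](C)(O)[C@H](CCCCC)O2` gives 3900 nM, and compound 2 `C=C1C2=C(C(=O)N1OC)[C@H](OC(=O)CSc1nc3ccccc3s1)[C@@](C)(O)[C@H](CCCCC)O2` gives 6300 nM; the only measured single step, a 1.6-fold higher number from compound 1 to compound 2 (0.21 log units; within the scatter), shows that swapping one ring for another within that ester hardly matters. Compound 4 `C=C1C2=C(C(=O)N1OC)[C@H](OC(=O)CCl)[C@@](C)(O)[C@H](CCCCC)O2` differs from compound 3 by (chloromethyl)carbonyl in place of hydrogen on an oxygen on a saturated carbon. Both compounds 1 and 2 carry an ester on that same oxygen and give lower numbers than compound 3, so an ester is expected to help here; compound 4 is estimated at 5000 nM, between 1500 nM and 16000 nM, an expected step of a 4.0-fold lower number from compound 3 to compound 4 (0.60 log units; beyond the scatter).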

Compound 4, half-maximal inhibitory concentration: 17000 nM
The estimate for compound 4 lay 3.4-fold (0.53 log units) below the measured number; measured number outside the range, above it.
By their numbers in this assay, from the lowest: compounds 1 and 2 (each within the scatter of the next); then compounds 4 and 3 (each within the scatter of the next).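

An ester on this oxygen is not enough on its own: with (chloromethyl)carbonyl in place of hydrogen there is a 1.2-fold lower number from compound 3 to compound 4 (0.07 log units; within the scatter), so compound 4 stays level with the free hydroxy compound. The lower numbers of compounds 1 and 2 therefore go with their sulfur-linked ring groups, not with the ester alone: chloro in their place gives a 2.7-fold higher number from compound 2 to compound 4 (0.43 log units; beyond the scatter) and a 4.4-fold higher number from compound 1 to compound 4 (0.64 log units; beyond the scatter). As far as these compounds go, whether an ester with a plain longer chain, or an amine in place of the chloro, would behave like compound 4 or like compounds 1 and 2 stays open. Nothing measured here explains these steps.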